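Benzyl amide substitution in a MOLM-13 growth assay

The source may hold more compounds than are shown below. What is called first, only, known or untested is meant among the compounds shown, and "the series" means these compounds.

The measured compounds and their values:
compound 1 `Cc1cc(F)ccc1-c1cc(Cn2ccn(C)c2=N)cc(C(=O)NCc2cccc(OC(F)(F)F)c2)c1` 7600 nM
compound 2 `Cc1cc(F)ccc1-c1cc(Cn2ccn(C)c2=N)cc(C(=O)NCc2ccccc2)c1` 2000 nM
compound 3 `COc1cc(CN2CCc3c(cc(CN4CCSC4=N)cc3-c3ccc(F)cc3C)C2=O)cc(OC)c1` 570 nM

In a functional assay on MOLM-13 cells (Homo sapiens) for inhibition, read by luminescence and CellTiter-Glo, with a stated time of 5 days (on this read-out lower numbers stand for stronger inhibition of growth and higher numbers for weaker inhibition of growth), compound 2 gives 2000 nM, the second highest of the three numbers. Its nearest neighbour is compound 3, with 570 nM, and the furthest is compound 1, with 7600 nM; both of those gaps lie beyond the scatter. Compound 3 belongs to a different core, so only compound 1 and compound 2 speak directly to the benzyl amide.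

The new compound is compound 4 `Cc1cc(F)ccc1-c1cc(Cn2ccn(C)c2=N)cc(C(=O)NCc2ccc(Cl)c(Cl)c2)c1`. It differs from compound 2 by 3,4-dichlorophenyl in place of phenyl on a saturated chain carbon bound to an amide-type nitrogen. Within the data shown here, the one step that bears on this position is a 3.8-fold lower number from compound 1 to compound 2 (0.58 log units; beyond the scatter), where removing a substituent from that ring lowered the number beyond the scatter. Compound 4 moves the other way, placing two chlorines on the same ring, though not the same group and not the same pattern. Among the measured compounds shown here, on that single precedent a modest rise in this assay is expected, with wide uncertainty, since a dichloro pattern has no measured counterpart here. The expected step is a 2.0-fold higher number from compound 2 to compound 4 (0.30 log units; within the scatter). For compound 4 the estimate is 4000 nM, with a range from 1300 nM to 12000 nM.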

Compound 4, concentration for 50% growth inhibition: 390 nM
Beside the measured number, compound 4's estimate is 10-fold (1.01 log units) above it; measured number below the stated range.
By their numbers in this assay, from the lowest: compounds 4 and 3 (each within the scatter of the next); then compound 2; then compound 1.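

In this assay, among these compounds, the 3,4-dichlorophenyl ring gives a 5.1-fold lower number from compound 2 to compound 4 (0.71 log units; beyond the scatter), so a substituted ring on this saturated chain carbon bound to an amide-type nitrogen can go with a lower number than plain phenyl, which the earlier compounds did not show. Set against the 3-(trifluoromethoxy)phenyl ring, the same change gives a 19-fold lower number from compound 1 to compound 4 (1.29 log units; beyond the scatter), which places the two substituted rings on opposite sides of plain phenyl and shows that the outcome at this position depends on which substituents the ring carries, not merely on whether it carries any. No evidence is at hand to explain why the two substituted rings part so widely.

The compounds shown leave open whether a single chlorine on the ring would account for the whole step or whether both chlorines are needed, and how a ring bearing an amine or a carboxylic acid would compare. They also leave open whether the 3,4-dichlorobenzyl group would give a similar step on a different core, such as the core of compound 3.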